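Ethoxy to propoxy on the shared flavanone core

A few compounds are considered here, and "the series" means these few. Any claim that something is new, unique, unknown or untested is made for them only; others in the source may bear on it.

Measured so far:
compound 1 `CCOc1ccc([C@@H]2CC(=O)c3cc(CC=C(C)C)c(OC)cc3O2)cc1` — 57%
compound 2 `COc1ccc([C@@H]2C/C(=N/O)c3cc(CC=C(C)C)c(OC)cc3O2)cc1` — 63%
compound 3 `COc1ccc([C@@H]2C/C(=N/OCc3cn(-c4ccc(C(N)=O)cc4)nn3)c3cc(CC=C(C)C)c(OC)cc3O2)cc1` — 100%

In a functional assay on MCF7 cells (Homo sapiens) for inhibition, read by sulforhodamine B assay, with a stated time of 48 h, tested at 50 uM (a higher number here means more inhibition of growth at the concentration tested, a lower number less inhibition of growth), compound 1 gives 57%, the lowest of the three numbers, though compound 2 at 63% lies within the scatter of it. Going by the values given here, compound 3 at 100% stands clearly beyond the scatter of compound 1; no single-point step links it to compound 1, so only the two values are compared here.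

Compound 4 `CCCOc1ccc([C@@H]2CC(=O)c3cc(CC=C(C)C)c(OC)cc3O2)cc1` differs from compound 1 by methyl in place of hydrogen on a saturated chain carbon, two bonds along the chain from an oxygen on an aromatic ring. Among the compounds with values here, no measured pair shows this change, so nothing sets its size. The step of no change at the digits printed from compound 1 to compound 4 (within the scatter) is expected to stay within the scatter, with no clear direction. For compound 4 a value around 57% is estimated, between 42% and 72%.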

Compound 4, percent growth inhibition at one concentration: 60%
Compound 4: the middle estimate sits 3 percentage points below what was measured; measured number inside the range.
By their numbers in this assay, from the lowest: compounds 1, 4 and 2 (each within the scatter of the next); then compound 3.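

In this assay, ethoxy to propoxy gives a number 3 percentage points higher from compound 1 to compound 4 (within the scatter), the first step measured at this place on the shared core. Methyl in place of hydrogen on this saturated chain carbon thus leaves compound 1 and compound 4 within the scatter of each other, so this one-carbon extension separates neither compound from the other. Nothing measured here bears on why the two values lie so close.

On these data alone, whether a longer chain such as butoxy, or a chain ending in an amine or a carboxylic acid, also stays within the scatter of compound 1 remains open. Also open, as far as these compounds go, is whether ethoxy to propoxy would behave the same way on the scaffold of compound 3.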